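The source may report more compounds than this note shows. Statements on the series, on what has been measured and on what is new or still open speak of the compounds shown alone.

Two selenium-bearing compounds built on one shared core have been tested in a functional assay on MCF7 cells (Homo sapiens) for cytotoxicity, read by MTT assay, with a stated time of 72 h; a lower number here means a stronger inhibitor of growth, a higher number a weaker inhibitor of growth. Compound 1 `C[Se]c1nc(N)c2cccnc2n1` gave only a limit of this assay, > 100000 nM, which is the limit of > 100000 nM in this assay, at which 1 of the 2 values shown sits. Among the measured compounds shown here, compound 2 `CCCCC[Se]c1nc([Se]CCCCC)c2cccnc2n1` gives 67700 nM in this assay, the only actual number among the two results, and a weak one. Compound 3 `CCCCC[Se]c1nc(N)c2cccnc2n1` has not yet been measured; it differs from compound 2 by one nitrogen atom in place of a group of 6 heavy atoms (5 carbon, 1 selenium; no ring), on an aromatic carbon. The step of a 1.3-fold higher number from compound 2 to compound 3 (0.12 log units; within the scatter) is expected to be small, toward weaker inhibition, if it lies beyond the scatter at all. Compound 3 is estimated at 90000 nM, within the range 40000 nM to 200000 nM.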

Compound 3, concentration for total growth inhibition: 53800 nM
Estimate against measurement, compound 3: 1.7-fold (0.22 log units) above; the range from low to high includes it.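

Putting amino in place of the group of 6 heavy atoms on this aromatic carbon gives a 1.3-fold lower number from compound 2 to compound 3 (0.10 log units; within the scatter), so the two compounds cannot be told apart in this assay. On the chain at the selenium atom, butyl in place of hydrogen gives an at least 1.8-fold lower number from compound 1 to compound 3 (0.26 log units; that floor lies within the scatter), so this step too cannot be shown to exceed the scatter. Compound 1 carries a limit, not a number: the limit of > 100000 nM in this assay, at which 1 of the 3 values shown sits.

Still open, on these data alone, is whether a longer chain on the selenium atom would give a step beyond the scatter. The same holds for a carboxylic acid in place of amino on this aromatic carbon.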